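The compounds below may be only part of what the source reports. "The series", "measured", "known", "first", "only" and "open" are said of these compounds alone.

Compound 1, with the structure `O=C(C1=C(O)C(=O)N(CCCn2ccnc2)C1c1ccc(Br)cc1)c1ccccc1`, and compound 2, with the structure `C[C@@H](NC1=C(C(=O)c2ccccc2)[C@@H](c2ccc(Br)cc2)N(CCCn2ccnc2)C1=O)c1ccccc1`, have both been tested in a functional assay on A549 cells (Homo sapiens) for antiproliferative activity, read by MTT assay, with a stated time of 72 h; a higher number here means a weaker inhibitor, a lower number a stronger inhibitor. In this assay compound 1 gives 73100 nM, while compound 2 gives 1970 nM, the lower of the two numbers and a gap that lies beyond the usual scatter. Compound 2 therefore stands as the stronger inhibitor of the pair that has been measured.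

Compound 3, with the structure `C[C@@H](NC1=C(C(=O)c2ccccc2)[C@H](c2ccc(Br)cc2)N(CCCn2ccnc2)C1=O)c1ccccc1`, has not yet been measured. Its relation to compound 2 is the two compounds have the same atoms and bonds and differ only in configuration as drawn: 1 of 2 stereo elements differ; a stereocentre at a saturated ring carbon is drawn R in compound 2 and S in compound 3. In words, the two compounds have the same atoms and bonds and differ only in configuration as drawn; a stereocentre at a saturated ring carbon is drawn R in compound 2 and S in compound 3. For the measured compounds named here, no step between measured compounds speaks to such a change, so its size and direction can only be guessed. A change of configuration at one stereocentre can leave potency unchanged or shift it considerably either way; the step from compound 2 to compound 3 is expected to be a 2.0-fold higher number from compound 2 to compound 3 (0.31 log units; beyond the scatter). Compound 3 is estimated to give 4000 nM, with a range from 800 nM to 25000 nM.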

Compound 3, half-maximal inhibitory concentration: 15700 nM
Compound 3: middle estimate off by 3.9-fold (0.59 log units), on the low side; the range from low to high includes it.
By their numbers in this assay, from the lowest: compound 2; then compound 3; then compound 1.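

Before this result, no pair of measured compounds could say whether the arrangement in space at the saturated ring carbon matters, as compound 1 and compound 2 differ in their atoms. In this assay, the drawn configuration at this one carbon does matter, with an 8.0-fold higher number from compound 2 to compound 3 (0.90 log units; beyond the scatter), so the R form as drawn in compound 2 is the stronger inhibitor of the pair and the S form in compound 3 the weaker. This gap can be tied to that single carbon and to no change of group, because nothing else separates the two structures: the fact that compounds 2 and 3 differ only in the configuration as drawn

On these data alone, the pair says nothing about the second stereocentre, which is drawn the same in compound 2 and compound 3, so the effect of inverting it, alone or together with the ring carbon, remains unknown. As far as these compounds go, it also remains open whether the R form would keep its advantage if the bromine on the phenyl ring gave way to a chlorine or a methoxy group, and the result gives no reason for the gap beyond the configuration itself.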